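The source may hold more compounds than are shown below. What is called first, only, known or untested is meant among the compounds shown, and "the series" means these compounds.

Of the compounds shown here, three built on one shared core have been tested in an assay on isolated protein for inhibition of Amine oxidase [flavin-containing] A (Homo sapiens), read by fluorescence and Amplex Red, with a stated time of 30 min, tested at 0.01 nM; on this read-out lower numbers stand for a weaker effect and higher numbers for a stronger effect at the one concentration tested. Compound 1 `CC(C)CNc1nnc(SCC(=O)N(Cc2cccc([N+](=O)[O-])c2)c2ccc(F)cc2)s1` gives 6.36%. Compound 2 `COCCNc1nnc(SCC(=O)N(Cc2cccc([N+](=O)[O-])c2)c2ccc(F)cc2)s1` gives 13.5%. Compound 3 `C=CCNc1nnc(SCC(=O)N(Cc2cccc([N+](=O)[O-])c2)c2ccc(F)cc2)s1` gives 10.3%. The three numbers lie close together: a number 3.9 percentage points higher from compound 1 to compound 3 (within the scatter) and a number 3.2 percentage points lower from compound 2 to compound 3 (within the scatter), so compound 3 is not set apart from either of the others by more than repeated measurements of this kind usually vary.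

The next compound, compound 4 `CC(C)Nc1nnc(SCC(=O)N(Cc2cccc([N+](=O)[O-])c2)c2ccc(F)cc2)s1`, is reached from compound 3 by a single change: isopropyl in place of allyl on a nitrogen on an aromatic ring. The step that bears on it most closely is the one in which isopropyl gave way to vinyl on a saturated chain carbon bound to a nitrogen on an aromatic ring, a number 3.9 percentage points higher from compound 1 to compound 3 (within the scatter), which stayed within the scatter; the swap of methoxymethyl for vinyl on the same kind of carbon, a number 3.2 percentage points lower from compound 2 to compound 3 (within the scatter), likewise moved nothing beyond it. Exchanging one small chain group for another at this position is therefore expected to give a number 1.3 percentage points lower from compound 3 to compound 4 (within the scatter), a step that does not rise above the scatter. Compound 4 is estimated at 9%, with a range from 0% to 19%.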

Compound 4, a percentage reported as inhibition, at one concentration (the size of the read-out at that concentration, not a potency): 6.87%
For compound 4 the middle estimate is 2.1 percentage points above the measured one, within the range that was stated.
By their numbers in this assay, from the lowest: compounds 1, 4, 3 and 2 (each within the scatter of the next).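

Compound 4 replaces the whole group on the nitrogen on an aromatic ring, and all three comparisons stay within the scatter: allyl to isopropyl (a number 3.4 percentage points lower from compound 3 to compound 4 (within the scatter)), 2-methoxyethyl to isopropyl (a number 6.6 percentage points lower from compound 2 to compound 4 (within the scatter)) and isobutyl to isopropyl (a number 0.5 percentage points higher from compound 1 to compound 4 (within the scatter)). Losing the double bond outside aromatic rings therefore leaves no readable mark, and the four groups at this position cannot be told apart on these numbers. No measurement at hand accounts for this closeness.

Going by these compounds, whether a longer chain, a phenyl ring or a chain ending in an amine or a carboxylic acid on this nitrogen would move the number beyond the scatter remains open. Every compound was read at a single concentration, so these numbers show only the size of the effect at that concentration.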